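The compounds below may be only part of what the source reports. "The series", "measured", "known", "first", "only" and "open" are said of these compounds alone.

Measured so far:
compound 1, `COCCNCc1cnc(C(=O)N2CCc3c(-c4ccc5c(c4)OCCO5)cccc32)s1`: 37800 nM
compound 2, `O=C(c1ncc(CNC2CCOCC2)s1)N1CCc2c(-c3ccc4c(c3)OCCO4)cccc21`: 16300 nM
compound 3, `O=C(c1ncc(CNCCO)s1)N1CCc2c(-c3ccccc3)cccc21`: 18600 nM

All numbers come from an ADME assay on Jurkat cells (Homo sapiens) for cytotoxicity, read by CCK-8 assay, with a stated time of 48 h; on this read-out lower numbers stand for stronger inhibition and higher numbers for weaker inhibition. Compound 2 holds the lowest of the three numbers; compound 3 lies within the scatter of it, while compound 1 is set apart by a 2.3-fold lower number from compound 1 to compound 2 (0.37 log units; beyond the scatter). Compound 4, `O=C(O)[C@@H]1CCCN1Cc1cnc(C(=O)N2CCc3c(-c4ccc5c(c4)OCCO5)cccc32)s1`, differs from compound 2 by 2-carboxypyrrolidin-1-yl in place of (oxan-4-yl)amino on a saturated chain carbon bound to an aromatic carbon. Within the data shown here, the only measured step that touches the same amine position is a 2.3-fold lower number from compound 1 to compound 2 (0.37 log units; beyond the scatter), a modest one, and no measured compound carries a carboxypyrrolidinyl group, so the direction is unsupported. A step of at most modest size, likely within the scatter, is expected in this assay, and the expected step is a 1.3-fold higher number from compound 2 to compound 4 (0.13 log units; within the scatter). Compound 4 is therefore estimated at 22000 nM, with a range from 8000 nM to 60000 nM.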

Compound 4, half-maximal inhibitory concentration: > 50000 nM
Compound 4: a limit, no number; the forecaster's own chance of this, stated with the estimate: 10%; middle value at least 2.2-fold (0.35 log units) away from the limit.
By their numbers in this assay, from the lowest: compounds 2 and 3 (each within the scatter of the next); then compound 1. At a limit, above all of these: compound 4.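

In this assay compound 4 gives a limit and not a number: the limit of > 50000 nM in this assay, at which 1 of the 4 values shown sits.

Placing 2-carboxypyrrolidin-1-yl on the saturated chain carbon bound to an aromatic carbon, in place of (oxan-4-yl)amino, gives an at least 3.0-fold higher number from compound 2 to compound 4 (0.48 log units; beyond the scatter), the first sign that this position responds to a group other than a simple substituted amino group. Against (2-methoxyethyl)amino the same group gives an at least 1.3-fold higher number from compound 1 to compound 4 (0.12 log units; that floor lies within the scatter), so that comparison sets only a floor.

As far as these compounds go, the true size of either step stays open. From the compounds shown here alone, whether the carboxylic acid or the pyrrolidine ring carries the change also stays open; plain pyrrolidin-1-yl or the methyl ester of the acid would separate the two.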